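The source may hold more compounds than are shown below. What is called first, only, known or untested is meant among the compounds shown, and "the series" means these compounds.

Working notes on the series. Compound 1 `CSc1nc(N)c2nc(O)n(Cc3ccccc3)c2n1` is the reference point of the pair measured so far; in a functional assay on the whole organism for activation, with Mus musculus as the target (on this read-out higher numbers stand for an effect only at larger amounts of compound and lower numbers for an effect already at smaller amounts), compound 1 gives 0.1 mg/kg, the lowest of the two numbers shown. Among the compounds with values here, compound 2 `CCCOc1nc(N)c2nc(O)n(Cc3ccccc3)c2n1` differs from compound 1 in one place, and in this assay compound 2 gives 0.3 mg/kg; the step of a 3.0-fold higher number from compound 1 to compound 2 (0.48 log units; beyond the scatter) is the only measured step in the set.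

Compound 3 `CCCCSc1nc(N)c2nc(O)n(Cc3ccccc3)c2n1` is not yet measured in this assay. Relative to compound 1 it carries propyl in place of hydrogen on a saturated chain carbon bound to a sulfur; cut one bond further out, the same change reads methylsulfanyl to butylsulfanyl. Within the data shown here, no measured step covers a lengthening of the chain on the sulfur: the step from compound 1 to compound 2 replaces the whole methylsulfanyl by propoxy, a different kind of change, and the dose it reports is higher only modestly. Among the measured compounds shown here, there is therefore no direct precedent for compound 3, and no large step in either direction is expected; a shift within or just beyond the scatter, leaning toward a higher dose, is the working guess.

For compound 3 the estimated value in this assay is 0.2 mg/kg with a range of 0.07 mg/kg to 0.6 mg/kg, which corresponds to an expected step of a 2.0-fold higher number from compound 1 to compound 3 (0.30 log units; within the scatter).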

Compound 3, minimum effective dose: 0.3 mg/kg
Beside the measured number, compound 3's estimate is 1.5-fold (0.18 log units) below it, within the range that was stated.
By their numbers in this assay, from the lowest: compound 1; then compounds 2 and 3 (each within the scatter of the next).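

The sulfur can stay in place and the chain on it still matters: going from methylsulfanyl to butylsulfanyl in this assay gives a 3.0-fold higher number from compound 1 to compound 3 (0.48 log units; beyond the scatter), a modest step that the earlier pair could not separate from the exchange of the whole group. Butylsulfanyl and propoxy are not told apart at this position, with no change at the digits printed from compound 2 to compound 3 (within the scatter), so compound 1 keeps the lowest number of the three, and its methylsulfanyl is the only one of these groups whose steps to both others are beyond the scatter. Nothing in the data shown accounts for either step.

Going by these compounds, with only methylsulfanyl and butylsulfanyl on the sulfur, the shape of the dependence on chain length stays open: ethylsulfanyl and propylsulfanyl could lie anywhere around these numbers, and a longer chain such as hexylsulfanyl could move the dose further or leave it unchanged. Also open, on these data alone, is how a group of another kind on the same aromatic carbon, such as an amine or a methoxy, would compare with methylsulfanyl in this read-out.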